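The compounds below may be only part of what the source reports. "The series", "measured", "known", "first", "only" and "open" are said of these compounds alone.

Measured compounds: compound 1, `COC(=O)c1cnc(C(=O)CCc2ccc(Oc3ccccc3)cc2)o1`, and compound 2, `CNC(=O)c1cnc(C(=O)CCc2ccc(Oc3ccccc3)cc2)o1`.

In an assay for inhibition of Fatty-acid amide hydrolase 1 (Rattus norvegicus) (a higher number here means a weaker inhibitor, a lower number a stronger inhibitor), compound 1 gives 1.7 nM. In this assay compound 2 gives 11 nM, the higher of the two numbers; the gap is a 6.5-fold higher number from compound 1 to compound 2 (0.81 log units; beyond the scatter). Compound 3, `O=C(CCc1ccc(Oc2ccccc2)cc1)c1ncc(C(F)(F)F)o1`, is not yet measured. Change: trifluoromethyl in place of methylcarbamoyl on an aromatic carbon. Among the measured compounds shown here, only the one step bears on it, and that step changed the group on the same ring carbon, giving a 6.5-fold higher number from compound 1 to compound 2 (0.81 log units; beyond the scatter). The new group lacks the carbonyl entirely, so the direction is uncertain; a step back toward compound 1 is expected. For compound 3 in this assay the expected value is 5 nM, range 1.2 nM to 25 nM, meaning an expected step of a 2.2-fold lower number from compound 2 to compound 3 (0.34 log units; beyond the scatter).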

Compound 3, inhibition constant: 2 nM
Compound 3: middle estimate off by 2.5-fold (0.40 log units), on the high side; the range from low to high includes it.
By their numbers in this assay, from the lowest: compounds 1 and 3 (each within the scatter of the next); then compound 2.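

In this assay, the aromatic carbon next to the ring oxygen does not need a carbonyl-bearing group for a low number: trifluoromethyl gives a 5.5-fold lower number from compound 2 to compound 3 (0.74 log units; beyond the scatter), and a 1.2-fold higher number from compound 1 to compound 3 (0.07 log units; within the scatter). Of the three groups on this carbon, methylcarbamoyl alone stands apart, while methoxycarbonyl and trifluoromethyl cannot be told apart. Nothing available accounts for these differences.

Open, as far as these compounds go, is how a carboxylic acid, a nitrile or a plain hydrogen on this carbon would compare. Also open, from the compounds shown here alone, is whether the same order of groups holds with a longer chain on the shared core.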